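The source may hold more compounds than are shown below. What is called first, only, known or untested is meant among the compounds shown, and "the series" means these compounds.

The measured compounds:

Compound 1 `COc1ccc(/C=C\c2cc(OC)c(OC)c(OC)c2)cc1OCc1ccc(CN2C[C@H](O)C[C@@H]2C(=O)O)cc1`: in an ADME assay on HEK293 cells (Homo sapiens) for cytotoxicity, read by CCK-8 assay, with a stated time of 48 h (a lower number here means a stronger inhibitor, a higher number a weaker inhibitor), compound 1 gives > 50000 nM, a limit of the assay rather than a number.
Compound 2 `COc1ccc(/C=C\c2cc(OC)c(OC)c(OC)c2)cc1OCc1ccc(CN2CCCCC2C(=O)O)cc1`: in this assay compound 2 gives > 50000 nM, again only a limit.
Compound 3 `COc1ccc(/C=C\c2cc(OC)c(OC)c(OC)c2)cc1OCc1ccc(CN2CC[C@@H](C(=O)O)C2)cc1`: in this assay compound 3 gives 27000 nM.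

Compound 2 therefore stands at the limit of > 50000 nM in this assay, at which 2 of the 3 values shown sit, and nothing shown places it anywhere beneath that. Among the measured compounds shown here, the one readable step out of it, an at least 1.8-fold lower number from compound 2 to compound 3 (0.26 log units; that floor lies within the scatter), has a floor that sits within the scatter, and the step that the two limits leave unreadable from compound 1 to compound 2 is unreadable because both ends are limits. Compound 4 `COc1ccc(/C=C\c2cc(OC)c(OC)c(OC)c2)cc1OCc1ccc(CN[C@H](C(=O)O)[C@@H](C)O)cc1` carries the change ((1-carboxy-2-hydroxypropyl)amino in place of 2-carboxypiperidin-1-yl on a saturated chain carbon bound to an aromatic carbon). For the measured compounds named here, the group that enters has no ring, where the group that leaves had one six-membered non-aromatic ring, but no measured step speaks to such a change, and all three measured values sit at or near the top of what the assay reports. The account is written before any measurement of compound 4 in this assay is known.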

Compound 4, half-maximal inhibitory concentration: > 50000 nM
Compound 4: a limit, no number; the forecaster's own chance of this, stated with the estimate: 70%; the middle value lies on the limit itself.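

In this assay compound 4 gives > 50000 nM, a limit of the assay and not a number. The first change shown to remove the ring, from 2-carboxypiperidin-1-yl to (1-carboxy-2-hydroxypropyl)amino on a saturated chain carbon bound to an aromatic carbon, therefore leaves the read-out at that limit, and compound 2 holds its place: the limit of > 50000 nM in this assay, at which 3 of the 4 values shown sit. The only readable step is an at least 1.8-fold higher number from compound 3 to compound 4 (0.26 log units; that floor lies within the scatter), while the steps to compound 4 from compound 1 and compound 2 have limits at both ends and cannot be read.

From the compounds shown here alone, how far compound 1, compound 2 and compound 4 lie beyond the limit stays open. Also open, going by these compounds, is whether a plain amine or an amide in place of the carboxylic acid on this chain would give a number within the range of the assay.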